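Oral exposure across a small ether-linked series

The compounds below may be only part of what the source reports. "The series", "measured", "known", "first", "only" and "open" are said of these compounds alone.

- compound 1 `CC(Oc1nn(-c2ccccc2F)c2ccc(F)cc12)C(=O)N1CCOCC1` gives 27%
- compound 2 `O=C1NCCN1CCOc1nn(-c2ccccc2F)c2ccc(F)cc12` gives 17%
- compound 3 `Fc1ccc2c(c1)c(OCCn1ccnc1)nn2-c1ccccc1F` gives 28%

In an ADME assay on the whole organism (strain Sprague-Dawley) for pharmacokinetics, with Rattus norvegicus as the target, read by LC-MS (a lower number here means that a smaller share of the oral dose reaches the circulation, a higher number that a larger share of the oral dose reaches the circulation), compound 3 stands at 28% and lies within the scatter of compound 1 but clear of compound 2. Among the measured compounds shown here, the only measured step in the set is a number 11 percentage points higher from compound 2 to compound 3 (beyond the scatter) and it exchanged 2-oxoimidazolidin-1-yl for 1H-imidazol-1-yl on the same chain.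

Compound 4 `O=C(COc1nn(-c2ccccc2F)c2ccc(F)cc12)N1CCOCC1` has not yet been measured. Its difference from compound 3 is (morpholin-4-yl)carbonyl in place of (1H-imidazol-1-yl)methyl on a saturated chain carbon bound to an oxygen on an aromatic ring and in words (morpholin-4-yl)carbonyl stands in place of (1H-imidazol-1-yl)methyl on a saturated chain carbon bound to an oxygen on an aromatic ring.

Two pieces of evidence bear on this change. The measured step on this chain, a number 11 percentage points higher from compound 2 to compound 3 (beyond the scatter), was modest, which gives no reason to expect a large move here. For the measured compounds named here, compound 1 also carries (morpholin-4-yl)carbonyl and gives 27% in this assay, so that group has at least one measured value within the scatter of compound 3, although no measured step isolates it. The expected result is therefore no shift beyond the scatter, and the estimated change is a number 3 percentage points lower from compound 3 to compound 4 (within the scatter) in either direction of little weight. Compound 4 is estimated at 25% (expected range 13% to 39%).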

Compound 4, oral bioavailability: 22%
Compound 4: the middle estimate sits 3 percentage points above what was measured; the range from low to high includes it.
By their numbers in this assay, from the lowest: compounds 2, 4, 1 and 3 (each within the scatter of the next, the first and the last beyond it).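

In this assay, the exchange on a saturated chain carbon bound to an oxygen on an aromatic ring gave a number 6 percentage points lower from compound 3 to compound 4 (within the scatter), and the corresponding exchange starting from the 2-oxoimidazolidin-1-yl compound gave a number 5 percentage points higher from compound 2 to compound 4 (within the scatter), so compound 4 cannot be told apart from either, even though a number 11 percentage points higher from compound 2 to compound 3 (beyond the scatter) is a separation that does clear the scatter. The methyl on the chain carbon also gains nothing that can be read, since hydrogen in its place gave a number 5 percentage points lower from compound 1 to compound 4 (within the scatter), and the (morpholin-4-yl)carbonyl compounds therefore stay together within the scatter in this assay. No measurement shown here offers an account of these small differences.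

As far as these compounds go, what remains open is whether any group at this place can carry the oral dose clearly past the values seen so far, for instance a carboxylic acid, a piperazine amide or a longer chain in place of the (morpholin-4-yl)carbonyl arrangement. Among the compounds shown here, the single methyl step also leaves open whether a larger group on that chain carbon, such as ethyl, would behave as methyl does, and whether these readings would hold on a core other than the shared one.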